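Adding a Fluorine to the Fused Ring of Compound 3

This account rests on a few compounds, and the source may have more. Where it says the series, first, only, none or still open, it means among the compounds named here.

Measured so far:
- compound 1, `O=C(Nc1nc2ccc(F)cc2s1)c1cn(-c2ccccc2)nc1-c1ccccc1`: 17600 nM
- compound 2, `O=C(Nc1nc2ccc(F)cc2s1)c1cn(-c2ccccc2)nc1-c1ccc(F)cc1`: 16700 nM
- compound 3, `O=C(Nc1nc2ccccc2s1)c1cn(-c2ccccc2)nc1-c1ccc(Cl)cc1`: 39600 nM

All three were tested in an ADME assay on HEK-293T cells (Homo sapiens) for cytotoxicity, read by MTT assay, with a stated time of 72 h; on this read-out higher numbers stand for weaker inhibition and lower numbers for stronger inhibition. Compound 3 gives the highest number of the three, meaning it is the weakest at killing these cells; the nearest is compound 1, and the gap between them is beyond the scatter, as is the gap to compound 2. Compound 4, `O=C(Nc1nc2ccc(F)cc2s1)c1cn(-c2ccccc2)nc1-c1ccc(Cl)cc1`, has not yet been measured. It differs from compound 3 by fluoro in place of hydrogen on an aromatic carbon.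

Within the data shown here, only one measured step changes a single group: a 1.1-fold lower number from compound 1 to compound 2 (0.02 log units; within the scatter), and that step concerns a fluorine on a different ring, so it bears on the present change only loosely. It suggests that a single fluorine on an aromatic ring does not move the number much. Compound 3 and compound 1 differ in two places, so their gap cannot be assigned to the fused-ring fluorine alone. The expectation for compound 4 is therefore a number close to that of compound 3, perhaps slightly lower, with the step from compound 3 to compound 4 expected at a 1.4-fold lower number from compound 3 to compound 4 (0.15 log units; within the scatter). Compound 4 is estimated at 28000 nM, with a range from 11000 nM to 65000 nM.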

Compound 4, half-maximal inhibitory concentration: > 50000 nM
Compound 4: a limit, no number; the forecaster's own chance of this, stated with the estimate: 10%; at least 1.7-fold (0.25 log units) between middle value and limit.
By their numbers in this assay, from the lowest: compounds 2 and 1 (each within the scatter of the next); then compound 3. At a limit, above all of these: compound 4.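

In this assay compound 4 gives > 50000 nM, which is a limit of the assay and not a number, and it is the only value of the set that sits there: the limit of > 50000 nM in this assay, at which 1 of the 4 values shown sits.

Placing 6-fluoro-1,3-benzothiazol-2-yl where compound 3 has 1,3-benzothiazol-2-yl gives an at least 1.2-fold higher number from compound 3 to compound 4 (0.10 log units; that floor lies within the scatter), so this fluoro shows no sign of lowering the number on a core that carries chloro, and the floor of the step stays within the scatter, much like the one fluoro-for-hydrogen step seen earlier: the same change on two cores in this assay, a 1.1-fold lower number (0.02 log units; within the scatter) from compound 1 to compound 2 and an at least 1.2-fold higher number (0.10 log units; that floor lies within the scatter) from compound 3 to compound 4; the limit leaves it open whether they differ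

With the fluoro on the fused system kept in place, chloro in place of fluoro on an aromatic carbon gives an at least 2.9-fold higher number from compound 2 to compound 4 (0.47 log units; beyond the scatter), and chloro in place of hydrogen gives an at least 2.8-fold higher number from compound 1 to compound 4 (0.45 log units; beyond the scatter), so here a single change of this kind moves the number beyond the scatter, which neither fluoro step has been shown to do.

On these data alone, since the limit hides the real value of compound 4, how far the fluoro step truly reaches remains open. The compounds shown also leave open how a methoxy group or an amine, set where the chloro or the fluoro now stands, would move the number.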